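A few compounds are considered here, and "the series" means these few. Any claim that something is new, unique, unknown or untested is made for them only; others in the source may bear on it.

Of the compounds shown here, three that share one core have been tested in a functional assay on Glioma cells (Homo sapiens) for inhibition, read by MTT assay, with a stated time of 72 h (a higher number here means a weaker inhibitor, a lower number a stronger inhibitor), and they differ only in the amine group attached to it. Compound 1 `C/C1=C\CC[C@@]2(C)O[C@@H]2[C@H]2OC(=O)[C@@H](CN3CCCCC3)[C@@H]2C[C@H]1O`, with piperidin-1-yl, gives 4000 nM. Compound 2 `C/C1=C\CC[C@@]2(C)O[C@@H]2[C@H]2OC(=O)[C@@H](CN3CCN(C)CC3)[C@@H]2C[C@H]1O`, with 4-methylpiperazin-1-yl, gives 36000 nM, which is a 9.0-fold higher number from compound 1 to compound 2 (0.95 log units; beyond the scatter). Compound 3 `C/C1=C\CC[C@@]2(C)O[C@@H]2[C@H]2OC(=O)[C@@H](CN3CCN(c4ccccc4)CC3)[C@@H]2C[C@H]1O` has phenyl in place of methyl on the amine nitrogen in the ring and gives 5000 nM, which is a 7.2-fold lower number from compound 2 to compound 3 (0.86 log units; beyond the scatter). Compound 3 therefore stands level with compound 1 within the scatter, and both are clearly stronger than compound 2.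

Compound 4 `COc1ccc(N2CCN(C[C@@H]3C(=O)O[C@H]4[C@H]3C[C@@H](O)/C(C)=C/CC[C@@]3(C)O[C@H]43)CC2)cc1` keeps all of compound 3 except for one change, methoxy in place of hydrogen on an aromatic carbon, para to a large group, turning phenyl into 4-methoxyphenyl. Within the data shown here, no measured compound carries any group on this phenyl, so no step speaks to the change directly. The two measured steps are only loose guides, and both replaced a whole group on the amine ring rather than adding to one. The closest is the one that introduced the phenyl in compound 3, a 7.2-fold lower number from compound 2 to compound 3 (0.86 log units; beyond the scatter). The step expected in this assay is therefore none beyond the scatter, a 1.1-fold lower number from compound 3 to compound 4 (0.05 log units; within the scatter). For compound 4 the estimated value is 4500 nM, with an expected range from 1800 nM to 12000 nM.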

Compound 4, half-maximal inhibitory concentration: 18000 nM
Estimate against measurement, compound 4: 4.0-fold (0.60 log units) below, and the stated range ends below it.
By their numbers in this assay, from the lowest: compounds 1 and 3 (each within the scatter of the next); then compounds 4 and 2 (each within the scatter of the next).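

In this assay, the phenyl of compound 3 had until now been seen only without any substituent, and placing methoxy on an aromatic carbon of that ring, para to a large group, gives a 3.6-fold higher number from compound 3 to compound 4 (0.56 log units; beyond the scatter), so this carbon does not tolerate every addition without change. An addition of only 2 heavy atoms is enough to cancel much of the earlier benefit of replacing methyl with phenyl on the amine nitrogen: the direct comparison of 4-methoxyphenyl with methyl on that nitrogen gives a 2.0-fold lower number from compound 2 to compound 4 (0.30 log units; within the scatter), which leaves the two compounds indistinguishable in this assay. Nothing measured here offers a reason for the rise seen with methoxy.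

Whether the rise belongs to methoxy in particular or would follow any group on this carbon stays open: among the compounds shown, this carbon carries only hydrogen or methoxy, and a chlorine atom, a hydroxyl or a methyl there would help to separate the two readings. It is also unknown whether methoxy on a different carbon of the same phenyl ring would give a similar step.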